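Swapping pyrazin-2-yl for 2,5-dimethoxyphenyl in the series

The compounds below may be only part of what the source reports. "The series", "measured", "known", "first", "only" and "open" are said of these compounds alone.

In a functional assay on HOS-TE85 cells (Homo sapiens) for inhibition, read by CCK-8 assay, with a stated time of 72 h (a higher number here means a weaker inhibitor, a lower number a stronger inhibitor), compound 3 (`O=C(NCCCCc1ccccc1)c1cccc(C2SCC(=O)N2c2cnccn2)c1`) gives > 1000 nM as a limit and not a number.

Compound 1 (`COc1ccc(C)cc1N1C(=O)CSC1c1cccc(C(=O)NCCCCc2ccccc2)c1`) gives 300 nM and compound 2 (`Cc1ccnc(N2C(=O)CS[C@@H]2c2cccc(C(=O)NCCCCn3cccn3)c2)c1`) gives 21.9 nM in this assay but compound 2 differs from compound 3 in more than one place.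

Among the compounds with values here, compound 4 (`COc1ccc(OC)c(N2C(=O)CSC2c2cccc(C(=O)NCCCCc3ccccc3)c2)c1`) carries 2,5-dimethoxyphenyl in place of pyrazin-2-yl on an amide-type nitrogen in a ring (the only structural change).

Within the data shown here, one measured step bears on it: an at least 3.3-fold higher number from compound 1 to compound 3 (0.52 log units; beyond the scatter) (beyond the scatter), with pyrazin-2-yl replacing 2-methoxy-5-methylphenyl at the same place. Compound 4 reverses that kind of change with a different substituted phenyl, so a return towards compound 1 at 300 nM is expected.

The estimated step is an at least 3.3-fold lower number from compound 3 to compound 4 (0.52 log units; beyond the scatter) towards a lower number in this assay and thus a stronger inhibitor.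

For compound 4 the expected value is 300 nM with an estimated range from 100 nM to 900 nM as the upper end.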

Compound 4, half-maximal inhibitory concentration: > 1000 nM
Compound 4: a limit, no number (the forecaster's own chance of this, stated with the estimate: 10%); middle value at least 3.3-fold (0.52 log units) from the limit.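

In this assay compound 4 gives > 1000 nM, which is a limit of the assay and not a number. Methoxy in place of methyl on an aromatic carbon gives an at least 3.3-fold higher number from compound 1 to compound 4 (0.52 log units; beyond the scatter), so a substituted phenyl on the amide-type nitrogen does not by itself keep the activity of compound 1, and this one change on that phenyl is enough to lose it. The step between compound 3 and compound 4 cannot be read, so pyrazin-2-yl and 2,5-dimethoxyphenyl cannot be ranked against each other, and the comparison stops at this limit: the limit of > 1000 nM in this assay, at which 2 of the 4 values shown sit.

Open, going by these compounds, is whether an ethyl group or a chlorine in place of the methyl of compound 1 would hold its activity. Also open, on these data alone, is how much of the value of compound 2, 21.9 nM, belongs to the group on its amide-type nitrogen and how much to its amide chain.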